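The source may hold more compounds than are shown below. What is called first, only, known or untested is meant among the compounds shown, and "the series" means these compounds.

In a physicochemical assay for lipophilicity, in phosphate buffer, measured as octanol-water partition, at pH 11.5 (on this read-out lower numbers stand for lower lipophilicity and higher numbers for higher lipophilicity), compound 3 `CCCCCCCCCCNC(=N)NC(=N)Nc1ccc(Cl)cc1` gives 6.13, the highest of the three numbers, while compound 2 `CCCCCCCCNC(=N)NC(=N)Nc1ccc(Cl)cc1` gives 5.13 and compound 1 `CCCCC(CC)CNC(=N)NC(=N)Nc1ccc(Cl)cc1` gives 4.93. Compound 4 `CCCCNC(=N)NC(=N)Nc1ccc(Cl)cc1` differs from compound 3 by hydrogen in place of hexyl on a saturated chain carbon, four bonds along the chain from an amine nitrogen, which is hydrogen in place of hexyl on a saturated chain carbon, four bonds along the chain from an amine nitrogen. The nearest guide is a number 1.00 log units higher from compound 2 to compound 3 (beyond the scatter), a modest step beyond the scatter for ethyl in place of hydrogen. The other measured step, a number 0.20 log units higher from compound 1 to compound 2 (within the scatter), lies within the scatter and offers little guidance. Since hexyl is a larger group than ethyl and is being removed, a much larger step towards lower numbers is expected, if the change scales with the chain lost. The expected step is a number 3.00 log units lower from compound 3 to compound 4 (beyond the scatter). For compound 4 the estimated value is 3.13, within an expected range of 2.6 to 3.7.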

Compound 4, partition coefficient: 3.13
Compound 4: the middle estimate sits on the measured number at the digits printed; low and high end bracket the measured number.
By their numbers in this assay, from the lowest: compound 4; then compounds 1 and 2 (each within the scatter of the next); then compound 3.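

In this assay compound 4, with the shortest chain shown, sets the low end of the series, and removing hexyl gives the largest step so far (a number 3.00 log units lower from compound 3 to compound 4 (beyond the scatter)). Removing butyl also gives large steps from the straight chain (a number 2.00 log units lower from compound 2 to compound 4 (beyond the scatter)) and from the branched chain (a number 1.80 log units lower from compound 1 to compound 4 (beyond the scatter)). With the earlier step (a number 1.00 log units higher from compound 2 to compound 3 (beyond the scatter)), the straight chains of compounds 4, 2 and 3 now give numbers that rise with chain length, and none of the three goes against this.

On these data alone, whether a longer chain, or a chain ending in a carboxylic acid, would follow the same trend remains open. Nothing shown here accounts for the size of these steps.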